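Swapping bromo for methoxy on a naphthyl semicarbazone

This account rests on a few compounds, and the source may have more. Where it says the series, first, only, none or still open, it means among the compounds named here.

Compound 1 `O=C(N/N=C/c1ccc(O)cc1)Nc1cccc2ccccc12`: 100 mg/kg
Compound 2 `O=C(N/N=C/c1ccccc1)Nc1cccc2ccccc12`: 300 mg/kg
Compound 3 `O=C(N/N=C/c1ccc(Br)cc1)Nc1cccc2ccccc12`: 300 mg/kg

In a functional assay on the whole organism (strain Swiss albino) with Mus musculus as the target, in the maximal electroshock model, with a stated time of 0.5 h (on this read-out higher numbers stand for an effect only at larger amounts of compound and lower numbers for an effect already at smaller amounts), compound 3 stands level with compound 2 at the digits shown, the two together giving the highest numbers; compound 1 gives a number lower by a 3.0-fold higher number from compound 1 to compound 3 (0.48 log units; beyond the scatter). Compound 4 `COc1ccc(/C=N/NC(=O)Nc2cccc3ccccc23)cc1` differs from compound 3 in one place: methoxy in place of bromo on an aromatic carbon. Two earlier steps bear on this position: a 3.0-fold higher number from compound 1 to compound 3 (0.48 log units; beyond the scatter) and no change at the digits printed from compound 2 to compound 3 (within the scatter). A hydroxy group lowered the dose, while hydrogen and bromo sat level, so a methoxy group might fall anywhere between those outcomes. Compound 4 is therefore expected to show a 1.5-fold lower number from compound 3 to compound 4 (0.18 log units; within the scatter), a step within the scatter. The estimate for compound 4 is 200 mg/kg, with a range from 100 mg/kg to 300 mg/kg.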

Compound 4, minimum effective dose: 300 mg/kg
Estimate against measurement, compound 4: 1.5-fold (0.18 log units) below, within the range that was stated.
By their numbers in this assay, from the lowest: compound 1; then compounds 2, 3 and 4 (each within the scatter of the next).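

In this assay, methoxy sits level with bromo and hydrogen, not with hydroxy (no change at the digits printed from compound 3 to compound 4 (within the scatter); no change at the digits printed from compound 2 to compound 4 (within the scatter)). A methyl on the oxygen of compound 1 gives a clear step (a 3.0-fold higher number from compound 1 to compound 4 (0.48 log units; beyond the scatter)), so among these compounds an oxygen on the ring is not enough: only the free hydroxy of compound 1 goes with the smaller dose. Nothing available explains this difference.

As far as these compounds go, whether an amine or a carboxylic acid here would match compound 1 or compound 4 remains open, as does the effect of a longer chain such as ethoxy.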